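This account rests on a few compounds, and the source may have more. Where it says the series, first, only, none or still open, it means among the compounds named here.

Compound 1, `CCCc1cc(OC)c2cc(NC(=O)/C=C/c3ccc(C(F)(F)F)cc3)ccc2n1`: 26 nM
Compound 2, `CCCc1ccc(/C=C/C(=O)Nc2ccc3nc(CCC)cc(N)c3c2)cc1`: 4 nM
Compound 3, `CC(C)c1cc(N)c2cc(NC(=O)/C=C/c3ccc(C(F)(F)F)cc3)ccc2n1`: 2.1 nM

Of the compounds shown here, three have been measured in an assay on isolated protein for displacement of a labelled ligand from melanin-concentrating hormone receptor 1 (Homo sapiens); a lower number here means a stronger inhibitor, a higher number a weaker inhibitor. Compound 2 gives 4 nM, the second highest of the three numbers. Compound 3, with 2.1 nM, lies within the scatter of compound 2, so the two cannot be told apart. Compound 1, with 26 nM, lies beyond the scatter from compound 2, and in that pair compound 2 shows the lower number.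

Compound 4, `CCCc1cc(N)c2cc(NC(=O)/C=C/c3ccc(C(C)(C)C)cc3)ccc2n1`, has not yet been measured in this assay. Against compound 2 it differs in one place: tert-butyl in place of propyl on an aromatic carbon. For the measured compounds named here, no measured pair in this set shows such a change, so the size of the step rests on expectation alone. The groups that leave and enter are both small carbon chains without ring, donor, acceptor or charge, and compound 3 carries a different group at the same place while sitting within the scatter of compound 2.

The step of no change at the digits printed from compound 2 to compound 4 (within the scatter) is therefore expected to be small, not beyond the scatter, in either direction. Compound 4 is estimated at 4 nM, with a range from 1.5 nM to 12 nM.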

Compound 4, half-maximal inhibitory concentration: 22 nM
The estimate for compound 4 lay 5.5-fold (0.74 log units) below the measured number; measured number outside the range, above it.
By their numbers in this assay, from the lowest: compounds 3 and 2 (each within the scatter of the next); then compounds 4 and 1 (each within the scatter of the next).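

In this assay, the place on the six-membered aromatic ring of carbon only, para to a large group, responds to an exchange between two small carbon chains: tert-butyl in place of propyl gives a 5.5-fold higher number from compound 2 to compound 4 (0.74 log units; beyond the scatter). For the compounds shown here, none of the earlier compounds formed a pair differing at this place alone, so this is the first direct reading here, and it shows that a step beyond the scatter can arise even though neither group carries a ring, donor, acceptor or charge. No measurement shown here accounts for the size of this step.

Going by these compounds alone, with only this one pair speaking to the place, it remains open how an ethyl group, a straight butyl chain or a single chlorine atom would behave there. Going by these compounds, it is equally open whether the same exchange would give a step of similar size on a core carrying a methoxy group in place of the amine.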